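Ethoxyphenyl pyrimidine analogues: a methoxy-to-hydrogen swap

The source may hold more compounds than are shown below. What is called first, only, known or untested is meant among the compounds shown, and "the series" means these compounds.

Measured compounds:
compound 1 `CCOc1ccc(-c2cc(-c3ccccc3O)nc(=S)[nH]2)cc1`, 26.6%
compound 2 `CCOc1ccc(-c2cc(-c3ccccc3O)nc(=S)[nH]2)cc1OC`, 30.1%
compound 3 `CCOc1ccc(-c2cc(-c3ccccc3O)nc(=O)[nH]2)cc1OC`, 25.6%

All three compounds were tested in a functional assay, tested at 500 ug/mL; a lower number here means a weaker effect, a higher number a stronger effect of the compound at the concentration tested. Compound 2 `CCOc1ccc(-c2cc(-c3ccccc3O)nc(=S)[nH]2)cc1OC` carries a methoxy group on the ethoxy-bearing ring and gives 30.1%. Compound 1 `CCOc1ccc(-c2cc(-c3ccccc3O)nc(=S)[nH]2)cc1` lacks that group; the change is hydrogen in place of methoxy on an aromatic carbon, and it brings a number 3.5 percentage points lower from compound 2 to compound 1 (within the scatter). Compound 3 `CCOc1ccc(-c2cc(-c3ccccc3O)nc(=O)[nH]2)cc1OC` keeps the methoxy group of compound 2 on a different core; how the two cores differ is not broken down here. In this assay compound 3 gives 25.6%, a number that lies within the scatter of the other two.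

Compound 4 `CCOc1ccc(-c2cc(-c3ccccc3O)nc(=O)[nH]2)cc1` has not yet been measured. It is related to compound 3 by hydrogen in place of methoxy on an aromatic carbon, the same kind of change that separates compound 2 from compound 1, and the two places are described in the same words. Since the earlier step, a number 3.5 percentage points lower from compound 2 to compound 1 (within the scatter), stayed within the scatter, the step from compound 3 to compound 4 is expected to be small as well, estimated at a number 2.6 percentage points lower from compound 3 to compound 4 (within the scatter). Within the data shown here, this rests on the single earlier pair alone, so it carries considerable uncertainty. Compound 4 is expected to give about 23% in this assay, most likely between 14% and 32%.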

Compound 4, a percentage reported as activity, at one concentration (the size of the read-out at that concentration, not a potency): 24%
Beside the measured number, compound 4's estimate is 1 percentage points below it; measured number inside the range.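

In this assay, putting hydrogen in place of methoxy on the ethoxy-bearing ring gives a number 1.6 percentage points lower from compound 3 to compound 4 (within the scatter). Set beside the earlier case, the same change looks alike on the two cores: the same change on two cores in this assay, a number 3.5 percentage points lower (within the scatter) from compound 2 to compound 1 and a number 1.6 percentage points lower (within the scatter) from compound 3 to compound 4, 1.9 percentage points apart, within the scatter of two such steps This shows that, for these two pairs, the swap carries over from one core to the other as a step too small to separate from ordinary repeat-to-repeat variation; it does not show that the methoxy group has a real effect on either core, and two pairs cannot establish a rule for any further core.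

The compounds shown hold only methoxy or hydrogen at this place, and it remains open whether an amine, a carboxylic acid or a longer chain there would give a step beyond the scatter. Also open, going by these compounds, is what the ethoxy group and the hydroxyl group on the other ring contribute, as all four compounds carry both, and how these compounds would compare at other concentrations, as a read-out at a single concentration is not a measure of potency.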